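From Fluoro to Chloro: A Small Halogen Swap

The compounds below may be only part of what the source reports. "The series", "measured", "known", "first", "only" and "open" are said of these compounds alone.

Compound 1 `COc1ccc(C(=O)/C=C/c2cccc(F)c2)c2c1C=CC(C)(C)O2` was tested in a functional assay on K562 cells (Homo sapiens) for antiproliferative activity, read by MTT assay, with a stated time of 24 h; on this read-out lower numbers stand for stronger inhibition and higher numbers for weaker inhibition. In this assay compound 1 gives > 10000 nM, and this is a limit of the assay rather than a measured number. Compound 1 thus stands at the limit of > 10000 nM in this assay, at which 1 of the 3 values shown sits. Two other compounds with the same core were measured alongside it: compound 2 `COc1ccc(C(=O)/C=C/c2ccc3ccccc3c2)c2c1C=CC(C)(C)O2` gives 3670 nM in this assay, and compound 3 `COc1ccc(C(=O)/C=C/c2ccc3ccccc3n2)c2c1C=CC(C)(C)O2` gives 3020 nM. Compound 4 `COc1ccc(C(=O)/C=C/c2cccc(Cl)c2)c2c1C=CC(C)(C)O2` differs from compound 1 in a single place: chloro in place of fluoro on an aromatic carbon. Going by the values given here, no measured pair shows this change, so the expected step from compound 1 to compound 4 in this assay is a step that the limit leaves unreadable from compound 1 to compound 4, which is not expected to reach beyond the usual scatter. Compound 4 is therefore estimated at 12000 nM, with a likely range from 4000 nM to 40000 nM.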

Compound 4, half-maximal inhibitory concentration: > 10000 nM
Compound 4: no number, only a limit; the forecaster's own chance of this, stated with the estimate: 55%; the middle value lies beyond the limit too.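

Going by these compounds alone, compound 1 and compound 4 each give only a limit of the assay rather than a number, so no step between them can be read: the limit of > 10000 nM in this assay, at which 2 of the 4 values shown sit. Going by these compounds, whether 3-fluorophenyl and 3-chlorophenyl differ at all in this assay stays open.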